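Swapping Methyl for Chloro on a Weak Cell Inhibitor

The source may hold more compounds than are shown below. What is called first, only, known or untested is meant among the compounds shown, and "the series" means these compounds.

Compound 2 `Cc1ccc(NC(=S)N/N=C2\C(=O)N(Cc3ccc(F)cc3)c3ccc(F)cc32)cc1` and compound 1 `O=C1/C(=N\NC(=S)Nc2ccc(Cl)cc2)c2cc(F)ccc2N1Cc1ccc(F)cc1` share one core and differ in a single group. In a functional assay on L1210 cells (Mus musculus), with a stated time of 48 h (a higher number here means a weaker inhibitor, a lower number a stronger inhibitor), compound 2 gives 6200 nM, while compound 1 gives 154000 nM. The change between them, (chloro in place of methyl on an aromatic carbon), brought a 25-fold higher number from compound 2 to compound 1 (1.40 log units; beyond the scatter). Compound 3 `Cc1ccc(NC(=S)N/N=C2\C(=O)N(Cc3ccc(Cl)cc3)c3ccc(Br)cc32)cc1` is built on a different core; how its core differs from that of compound 2 is not broken down here. In this assay compound 3 reaches only >= 500000 nM, which is a limit of the measurement rather than a number, in line with the limit of >= 500000 nM in this assay, at which 1 of the 3 values shown sits. Compound 4 `O=C1/C(=N\NC(=S)Nc2ccc(Cl)cc2)c2cc(Br)ccc2N1Cc1ccc(Cl)cc1` has not yet been measured and arises from compound 3 by the same change, (chloro in place of methyl on an aromatic carbon), at the same place. Because the earlier step of a 25-fold higher number from compound 2 to compound 1 (1.40 log units; beyond the scatter) moved the number toward a weaker inhibitor, the step expected here is a step that the limit leaves unreadable from compound 3 to compound 4, again toward weaker. Compound 4 is therefore expected to give 1000000 nM, most likely again reported only as a limit.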

Compound 4, half-maximal inhibitory concentration: >= 500000 nM
Compound 4 gave a limit, no number; the forecaster's own chance of this, stated with the estimate: 85%; the middle value is on the limit's open side.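

In this assay, compound 3 and compound 4 both give only a limit of the measurement rather than a number, so no step between them can be read: the limit of >= 500000 nM in this assay, at which 2 of the 4 values shown sit.

The compounds shown leave open whether chloro in place of methyl changes anything on the core of compound 3, and by how much.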